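Replacing aminocarbamoyl with benzyl(methyl)amino on a shared core

A few compounds are considered here, and "the series" means these few. Any claim that something is new, unique, unknown or untested is made for them only; others in the source may bear on it.

Of the compounds shown here, three built on one shared core have been measured in an assay for inhibition of Amine oxidase [flavin-containing] B (Rattus norvegicus); on this read-out lower numbers stand for stronger inhibition and higher numbers for weaker inhibition. Compound 1 `NNC(=O)Cc1cc(=O)oc2cc(OCc3cccc(Cl)c3)ccc12` gives 90 nM. Compound 2 `NC(=O)Cc1cc(=O)oc2cc(OCc3ccccc3)ccc12` gives 200 nM, and compound 3 `NC(=O)Cc1cc(=O)oc2cc(OCc3ccncc3)ccc12` gives 2000 nM. Compound 1 therefore stands at the lowest number of the three, with compound 2 a step above it and compound 3 further above still. For the measured compounds named here, the only step between compounds that differ in a single place is a 10-fold higher number from compound 2 to compound 3 (1.00 log units; beyond the scatter), and it concerns the ring carried on the ether-linked chain, not the side chain on the core.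

Compound 4 `CN(Cc1ccccc1)Cc1cc(=O)oc2cc(OCc3cccc(Cl)c3)ccc12` changes that side chain instead: benzyl(methyl)amino in place of aminocarbamoyl on a saturated chain carbon bound to an aromatic carbon. Going by the values given here, none of the measured steps touches this position, so nothing among the measured compounds says how this assay responds to such a change; the only guidance is that the remainder of compound 4 is the same as in compound 1, which sits at the lowest number seen. In this assay the step expected from compound 1 to compound 4 is therefore a 3.3-fold higher number from compound 1 to compound 4 (0.52 log units; beyond the scatter), a cautious guess with a wide margin. Compound 4 is expected to give about 300 nM, within a range of 30 nM to 3000 nM.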

Compound 4, half-maximal inhibitory concentration: 8000 nM
For compound 4 the middle estimate is 27-fold (1.43 log units) below the measured one, outside the stated range (above it).
By their numbers in this assay, from the lowest: compound 1; then compound 2; then compound 3; then compound 4.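

In this assay the side chain on the shared core proves to be far from indifferent: benzyl(methyl)amino in place of aminocarbamoyl, on a saturated chain carbon bound to an aromatic carbon, gives an 89-fold higher number from compound 1 to compound 4 (1.95 log units; beyond the scatter), a step labelled large and the first measured at this position. Several things change together in this swap, since a group with no ring and 2 hydrogen-bond donors leaves and a group with more heavy atoms, a six-membered aromatic ring of carbon only and 0 hydrogen-bond donors enters, so the single step cannot be assigned to any one of these differences. No measurement is available here that would explain the size of this step.

As far as these compounds go, it remains open which of these differences carries the step, and a dimethylamino group or a plain primary amine on the same carbon would help separate the added benzyl ring from the loss of the carbonyl. Also open, from the compounds shown here alone, is how a carboxylic acid at this position would compare with compound 1 at 90 nM on the same core.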